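The compounds below may be only part of what the source reports. "The series", "measured", "known", "first", "only" and "open" are said of these compounds alone.

For the measured compounds named here, in a functional assay on MCF7 cells (Homo sapiens) for inhibition, read by MTT assay, with a stated time of 48 h, tested at 10 uM (on this read-out lower numbers stand for less inhibition of growth and higher numbers for more inhibition of growth at the one concentration tested), compound 1 `Cc1oc2c([C@H]3CCN(C)C[C@H]3O)c(O)cc(O)c2c(=O)c1C(O)c1cccc(Cl)c1` gives 5% and compound 2 `Cc1oc2c([C@H]3CCN(C)C[C@H]3O)c(O)cc(O)c2c(=O)c1C(O)c1csc([N+](=O)[O-])c1` gives 20% as the higher of the two numbers so far. Going by the values given here, the only measured step is a number 15 percentage points higher from compound 1 to compound 2 (beyond the scatter) and it is modest but beyond the scatter. That step puts 5-nitrothiophen-3-yl where 3-chlorophenyl stood, on a saturated chain carbon bound to an aromatic carbon and an oxygen on a saturated carbon. Compound 3 `Cc1oc2c([C@H]3CCN(C)C[C@H]3O)c(O)cc(O)c2c(=O)c1C(O)c1ccc(F)cc1` changes the same place, with 4-fluorophenyl in place of 5-nitrothiophen-3-yl, and the change counts out as 4-fluorophenyl in place of 5-nitrothiophen-3-yl on a saturated chain carbon bound to an aromatic carbon and an oxygen on a saturated carbon in full. Among the compounds with values here, no compound with 4-fluorophenyl has been measured. Compound 1 at 5% is the nearest measured case for the expectation: its 3-chlorophenyl, like 4-fluorophenyl, is a phenyl group carrying a halogen. Compound 3 is therefore expected to give back most of the modest gain, and the expected step is a number 11 percentage points lower from compound 2 to compound 3 (beyond the scatter) toward less inhibition of growth. With a single measured step the range stays wide. In this assay compound 3 is estimated at 9% with a range from 0% to 22% for now.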

Compound 3, percent growth inhibition at one concentration: 9%
Beside the measured number, compound 3's estimate shows no gap at the digits printed, and the stated range covers the measured number.
By their numbers in this assay, from the lowest: compounds 1 and 3 (each within the scatter of the next); then compound 2.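

In this assay, a second halogen-bearing phenyl group, on the saturated chain carbon bound to an aromatic carbon and an oxygen on a saturated carbon, falls in with the first. The change to 4-fluorophenyl gives a number 11 percentage points lower from compound 2 to compound 3 (beyond the scatter), while its comparison with 3-chlorophenyl gives a number 4 percentage points higher from compound 1 to compound 3 (within the scatter), so among these three compounds only the 5-nitrothiophen-3-yl group stands apart, and the switch from 3-chlorophenyl to 4-fluorophenyl does not separate the two phenyl cases at this position. Nothing available explains either step.

From the compounds shown here alone, it remains open whether the difference goes with the thiophene ring or with the nitro group, and a nitrophenyl group and a plain thiophene ring at this place would separate the two. Also open, going by these compounds, is how an amine or a carboxylic acid carried on the ring at this place would read, and whether any group here can go beyond compound 2 at 20%.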